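The source may hold more compounds than are shown below. What is called first, only, known or untested is meant among the compounds shown, and "the series" means these compounds.

Measured compounds:

- compound 1, `CC(O)(C(=O)Nc1ccc(S(=O)(=O)c2ccccc2)c(F)c1)C(F)(F)F`: 1800 nM
- compound 2, `CC(O)(C(=O)Nc1ccc(S(=O)(=O)c2cccc(F)c2)cc1)C(F)(F)F`: 3400 nM
- compound 3, `CC(O)(C(=O)Nc1ccc(C#N)c(S(=O)(=O)c2ccccc2)c1)C(F)(F)F`: 2600 nM

All three were tested in a functional assay (Cavia porcellus) with sulfonylurea receptors; K-ATP channels (Homo sapiens) as the target; a lower number here means a stronger inhibitor, a higher number a weaker inhibitor. Compound 1 shows the lowest of the three numbers, but its distance to compound 3 and to compound 2 lies within the scatter of repeated measurements, so the three cannot be placed in an order of strength on these data alone.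

Compound 4, `COc1cc(NC(=O)C(C)(O)C(F)(F)F)ccc1S(=O)(=O)c1ccccc1`, has not yet been measured in this assay. It is made from compound 1 by a single change: methoxy in place of fluoro on an aromatic carbon. For the measured compounds named here, no measured pair of compounds differs in exactly this way, so nothing among the measured compounds tells how large a shift this exchange produces. Going by the values given here, the three measured compounds, which differ from one another in the groups placed around the shared core, all sit within the scatter of each other, and that is the only guide available.

On that basis compound 4 is expected to land near compound 1, with the step of a 1.4-fold higher number from compound 1 to compound 4 (0.14 log units; within the scatter) expected to stay within the scatter. The estimate for compound 4 in this assay is 2500 nM, with a range from 900 nM to 7000 nM.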

Compound 4, half-maximal inhibitory concentration: 5900 nM
Compound 4: middle estimate off by 2.4-fold (0.37 log units), on the low side, within the range that was stated.
By their numbers in this assay, from the lowest: compounds 1, 3, 2 and 4 (each within the scatter of the next, the first and the last beyond it).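

In this assay, methoxy in place of fluoro on this aromatic carbon, ortho to a group of 9 heavy atoms and meta to a large group, gives a 3.3-fold higher number from compound 1 to compound 4 (0.52 log units; beyond the scatter) and so moves the reading by a modest amount. For the compounds shown here, this is the first comparison here between compounds that differ in one place, and it shows that this position does not tolerate every exchange without a measurable shift. No measurement at hand explains the shift, so the hydrogen-bond acceptor and the additional heavy atom that methoxy brings remain counted differences only.

As far as these compounds go, what the step depends on stays open: methyl, hydroxyl, chlorine or the longer ethoxy on the same carbon would help to separate the part played by the oxygen from that played by the carbon. From the compounds shown here alone, whether the same exchange gives a similar step elsewhere on the ring also remains unknown.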